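The compounds below may be only part of what the source reports. "The series", "measured", "known", "first", "only" and "open" are said of these compounds alone.

Working notes on the series.

For the measured compounds named here, compound 1 `COc1cc(C(=O)N(C)C)ccc1Nc1nc(OC(C)C)c2cc[nH]c2n1` is the weaker of the two measured members: in a functional assay on CAL-51 cells (Homo sapiens) for antiproliferative activity, read by luminescence and CellTiter-Glo, with a stated time of 3 days (on this read-out higher numbers stand for weaker inhibition and lower numbers for stronger inhibition), compound 1 gives 1270 nM, the highest number among the two recorded. Going by the values given here, the only other measured compound, compound 2 `C[C@@H](Oc1cc(C(=O)N(C)C)ccc1Nc1nc(O[C@H]2CC[C@@](C)(O)CC2)c2c(Cl)c[nH]c2n1)C(F)(F)F`, gives 10 nM in this assay, a far lower number, well beyond the scatter. Among the compounds with values here, compound 2 differs from compound 1 in several places at once, so its value shows only that much lower numbers are reachable within the shared core; no single change can be read from it.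

The next compound, compound 3 `COc1cc(C(=O)N(C)C)ccc1Nc1nc(OC2CCCCC2)c2cc[nH]c2n1`, changes compound 1 in one place only: cyclohexyl in place of isopropyl on an oxygen on an aromatic ring. Compound 2 also carries a six-membered carbon ring on that oxygen, but with further groups on it and with other changes elsewhere, so it does not isolate this step.

Some movement toward a lower number is expected from compound 1 to compound 3, estimated as a 3.2-fold lower number from compound 1 to compound 3 (0.50 log units; beyond the scatter), modest but probably beyond the scatter. Compound 3 is expected to give about 400 nM in this assay, within a range of 120 nM to 1500 nM.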

Compound 3, half-maximal inhibitory concentration: 190 nM
Beside the measured number, compound 3's estimate is 2.1-fold (0.32 log units) above it; the range from low to high includes it.
By their numbers in this assay, from the lowest: compound 2; then compound 3; then compound 1.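

In this assay, for the compounds shown here, the step of cyclohexyl in place of isopropyl on an oxygen on an aromatic ring gives a 6.7-fold lower number from compound 1 to compound 3 (0.83 log units; beyond the scatter) and is the first change that can be read at a single place. Going by these compounds alone, compound 2 showed only that much lower numbers are reachable within the shared core, whereas this pair ties a move beyond the scatter to the isopropoxy to cyclohexyloxy change alone, with the rest of compound 1 unchanged. Nothing on hand bears on the reason for this step, which remains an observation on one pair.

The compounds shown leave open whether the ring itself matters or only the added carbon, which a longer open chain or a cyclopentyl group on the same oxygen would help to separate. From the compounds shown here alone, the other changes carried by compound 2 cannot be read one by one, so the contributions of the hydroxyl and methyl groups on its six-membered ring, its chlorine on the core and its trifluoromethyl-bearing ether remain unknown.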